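The source may hold more compounds than are shown below. What is called first, only, known or untested is meant among the compounds shown, and "the series" means these compounds.

Measured compounds:
compound 1 `CO/C(O)=C1\C(C)=NC(C)=C(C(=O)OCCCN2C(=O)c3ccccc3S2(=O)=O)C1c1cccc([N+](=O)[O-])c1` – 2.6 nM
compound 2 `CO/C(O)=C1\C(C)=NC(C)=C(C(=O)OCCCN2C(=O)c3ccccc3S2(=O)=O)C1c1ccccc1[N+](=O)[O-]` – 1.5 nM
compound 3 `CO/C(O)=C1\C(C)=NC(C)=C(C(=O)OCCCN2C(=O)c3ccccc3S2(=O)=O)C1c1cccc(Cl)c1Cl` – 0.8 nM

In a functional assay (aorta) with Oryctolagus cuniculus as the target (on this read-out higher numbers stand for weaker inhibition and lower numbers for stronger inhibition), compound 3 gives the lowest of the three numbers. The two steps leading to it are a 1.9-fold lower number from compound 2 to compound 3 (0.27 log units; within the scatter) and a 3.3-fold lower number from compound 1 to compound 3 (0.51 log units; beyond the scatter). Compound 4 `CO/C(O)=C1\C(C)=NC(C)=C(C(=O)OCCCN2C(=O)c3ccccc3S2(=O)=O)C1c1ccccc1Cl` differs from compound 3 by hydrogen in place of chloro on an aromatic carbon. Within the data shown here, no measured pair removes a single chloro from this ring, so the bearing steps are indirect: the step of a 3.3-fold lower number from compound 1 to compound 3 (0.51 log units; beyond the scatter) and the step of a 1.9-fold lower number from compound 2 to compound 3 (0.27 log units; within the scatter) show that swapping the whole substituent pattern on this ring moves this assay only modestly. A small rise in number, expected to stay within the scatter, is therefore estimated for a 1.9-fold higher number from compound 3 to compound 4 (0.27 log units; within the scatter). Compound 4 is expected to give about 1.5 nM, in the range 0.6 nM to 4 nM.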

Compound 4, half-maximal inhibitory concentration: 1.8 nM
Compound 4: middle estimate off by 1.2-fold (0.08 log units), on the low side, and the stated range covers the measured number.
By their numbers in this assay, from the lowest: compounds 3, 2, 4 and 1 (each within the scatter of the next, the first and the last beyond it).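

Going from 2,3-dichlorophenyl to 2-chlorophenyl is the first change of a single atom on this ring, and in this assay it reads a 2.3-fold higher number from compound 3 to compound 4 (0.35 log units; beyond the scatter) so one chloro alone can carry a step beyond the scatter. Chloro in place of nitro reads a 1.2-fold higher number from compound 2 to compound 4 (0.08 log units; within the scatter) and 2-chlorophenyl in place of 3-nitrophenyl reads a 1.4-fold lower number from compound 1 to compound 4 (0.16 log units; within the scatter) so neither swap leaves the scatter. Nothing given here accounts for these steps.

Still open, on these data alone, is what an unsubstituted phenyl ring would give. Also open, as far as these compounds go, is how a methoxy or trifluoromethyl group would compare with this chloro.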